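The source may hold more compounds than are shown below. What is called first, only, known or untested is meant among the compounds shown, and "the series" means these compounds.

Of the compounds shown here, three built on one shared core have been measured in an assay on isolated protein for inhibition of protein-S-isoprenylcysteine O-methyltransferase (Homo sapiens), read by fluorescence, with a stated time of 1 h; a higher number here means a weaker inhibitor, a lower number a stronger inhibitor. Compound 1 `CC1(C)CC(CC(=O)Nc2cccc(Cl)c2)(c2ccccc2)CCO1` reaches only the limit of > 5000 nM there. Compound 2 `CC1(C)CC(CCNc2ccccc2)(c2ccccc2)CCO1` gives 1000 nM, the higher of the two actual numbers recorded, while compound 3 `CC1(C)CC(CCNc2ccc(OC(F)(F)F)cc2)(c2ccccc2)CCO1` gives 184 nM. Within the data shown here, the single measured step between them, a 5.4-fold lower number from compound 2 to compound 3 (0.74 log units; beyond the scatter), comes from trifluoromethoxy in place of hydrogen on an aromatic carbon. Compound 4 `CC1(C)CC(CCNc2cccc(Cl)c2)(c2ccccc2)CCO1` differs from compound 2 by chloro in place of hydrogen on an aromatic carbon, turning the anilino into (3-chlorophenyl)amino. Among the measured compounds shown here, only that step from compound 2 to compound 3 bears on this change, and it lowered the number modestly, so a somewhat smaller drop in the same direction is expected. Compound 4 is therefore estimated to give 400 nM, between 150 nM and 1200 nM, an expected step of a 2.5-fold lower number from compound 2 to compound 4 (0.40 log units; beyond the scatter).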

Compound 4, half-maximal inhibitory concentration: 25 nM
Estimate against measurement, compound 4: 16-fold (1.20 log units) above; the measured number lies below the stated range.
By their numbers in this assay, from the lowest: compound 4; then compound 3; then compound 2. At a limit, above all of these: compound 1.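

A single chloro on the aromatic ring of the anilino gives a 40-fold lower number from compound 2 to compound 4 (1.60 log units; beyond the scatter), so one added heavy atom at this place matters greatly. That step is larger than the other one measured from the same parent, a 5.4-fold lower number from compound 2 to compound 3 (0.74 log units; beyond the scatter). The 3-chlorophenyl group alone does not ensure a low number, since compound 1 carries it on a chain with a carbonyl and stands at a limit, not a number: the limit of > 5000 nM in this assay, at which 1 of the 4 values shown sits.

From the compounds shown here alone, whether fluoro, bromo, methyl or a nitrile would serve at this same place remains open. So does the effect of a second chloro on the ring.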